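Dimethoxyphenyl urea series: bromo for iodo on the aniline

This account rests on a few compounds, and the source may have more. Where it says the series, first, only, none or still open, it means among the compounds named here.

Inhibition in a functional assay on NCI-H226 cells (Homo sapiens) for inhibition, read by MTT assay, with a stated time of 48 h, tested at 10 uM (a higher number here means more inhibition at the concentration tested (going by the name of the read-out), a lower number less inhibition), measured so far:
compound 1 `COc1cc(NC(=O)Nc2cc(Nc3ccc(C(C)(C)C)cc3)ncn2)cc(OC)c1`: 47.7%
compound 2 `CCc1cccc(Nc2cc(NC(=O)Nc3cc(OC)cc(OC)c3)ncn2)c1`: 36.7%
compound 3 `COc1cc(NC(=O)Nc2cc(Nc3cc(I)ccc3OC)ncn2)cc(OC)c1`: 56.7%

Compound 3 holds the highest of the three numbers. One step towards it is a number 9 percentage points higher from compound 1 to compound 3 (within the scatter), which stays within the scatter, so those two cannot be ordered. The other step towards it is a number 20 percentage points higher from compound 2 to compound 3 (beyond the scatter), a modest step beyond the scatter, and compound 2 also sits below compound 1 by a number 11 percentage points lower from compound 1 to compound 2 (beyond the scatter).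

Compound 4 `COc1cc(NC(=O)Nc2cc(Nc3cc(Br)ccc3OC)ncn2)cc(OC)c1` differs from compound 3 by bromo in place of iodo on an aromatic carbon. Among the measured compounds shown here, all three measured steps exchange the whole aryl group on the nitrogen, and none exchanges one halogen for another while the rest of the ring is kept, so no measured step bears directly on this change. With no guidance from the series and a change of a single heavy atom, no step beyond the scatter is expected in this assay, with a slight downward lean; the estimated step is a number 4.7 percentage points lower from compound 3 to compound 4 (within the scatter). Compound 4 is therefore expected to give about 52%, in a range from 40% to 64%.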

Compound 4, a percentage reported as inhibition, at one concentration (the size of the read-out at that concentration, not a potency): 42.7%
Estimate against measurement, compound 4: 9.3 percentage points above; measured number inside the range.
By their numbers in this assay, from the lowest: compounds 2, 4, 1 and 3 (each within the scatter of the next, the first and the last beyond it).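

In this assay, among the compounds shown here, the single atom on the ring para to the methoxy group counts, with the rest of the compound kept: bromo in place of iodo gives a number 14 percentage points lower from compound 3 to compound 4 (beyond the scatter), the only step that changes one halogen alone. With bromo on the ring, the aryl groups on the nitrogen no longer separate, since a number 6 percentage points higher from compound 2 to compound 4 (within the scatter) and a number 5 percentage points lower from compound 1 to compound 4 (within the scatter) both stay within the scatter, so 5-bromo-2-methoxyphenyl cannot be ordered against 3-ethylphenyl or 4-(tert-butyl)phenyl. Nothing available explains the iodo to bromo step.

Open, going by these compounds, is whether chloro, fluoro or a non-halogen such as methyl or nitrile at this place would fall with bromo or with iodo. Also open, on these data alone, is how the iodo and bromo compounds would compare without the methoxy group on the ring.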